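Tetrazole for carboxylic acid on the quinolinylmethoxy-aryl series

This account rests on a few compounds, and the source may have more. Where it says the series, first, only, none or still open, it means among the compounds named here.

Of the compounds shown here, two have numbers so far. Compound 1 `CC(CCC(=O)O)Cc1cccc(OCc2ccc3ccccc3n2)c1` and compound 2 `O=C(O)CC1(CCc2ccc(OCc3ccc4ccccc4n3)cc2)CCCC1` were both run in an assay on membranes from lung (Cavia porcellus) for binding affinity to cysteinyl leukotriene receptor (Homo sapiens); on this read-out higher numbers stand for weaker inhibition and lower numbers for stronger inhibition. Compound 1 gives 140 nM, and compound 2 gives 51 nM; compound 1 thus stands at the higher of the two numbers, and the gap to compound 2 is beyond the scatter. For the measured compounds named here, no pair differing in a single place has been measured, so no step size is known from the numbers themselves.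

Compound 3 `c1cc(CCCCc2nnn[nH]2)cc(OCc2ccc3ccccc3n2)c1` has not yet been measured in this assay. It is drawn from compound 1 by one change: 3-(1H-tetrazol-5-yl)propyl in place of 3-carboxy-1-methylpropyl on a saturated chain carbon bound to an aromatic carbon. The acid and the tetrazole each keep one hydrogen-bond donor, while the tetrazole brings two more acceptors and an aromatic ring.

Going by the values given here, with no measured step to lean on, the expectation for compound 3 is a step of modest size, more likely toward a lower number than a higher one, though a result within the scatter of compound 1 would not surprise; the expected step is a 1.4-fold lower number from compound 1 to compound 3 (0.15 log units; within the scatter). Compound 3 is estimated at 100 nM, with a range from 30 nM to 400 nM.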

Compound 3, inhibition constant: 20 nM
Beside the measured number, compound 3's estimate is 5.0-fold (0.70 log units) above it; the whole stated range lies above it.
By their numbers in this assay, from the lowest: compound 3; then compound 2; then compound 1.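

Swapping 3-carboxy-1-methylpropyl for 3-(1H-tetrazol-5-yl)propyl on the saturated chain carbon bound to an aromatic carbon gives a 7.0-fold lower number from compound 1 to compound 3 (0.85 log units; beyond the scatter) in this assay, the first single-place step in the series, so this place accepts a five-membered aromatic ring with 4 hetero atoms instead of the carboxylic acid and the number improves well beyond the scatter. The change is not a clean exchange of one acid-bearing end for another, since the methyl branch of compound 1 leaves along with the carboxylic acid, and this one step holds both events without apportioning the gain between them. Nothing at hand on the properties of either group explains the size of the step.

Still open, on these data alone, is whether the gain follows the tetrazole or the loss of the methyl branch, a question that an unbranched 3-carboxypropyl chain or a 3-(1H-tetrazol-5-yl)-1-methylpropyl chain on the core of compound 1 would address. Also open, as far as these compounds go, is whether a longer or shorter chain carrying the tetrazole would hold the number of compound 3, and whether the same exchange would give a step of similar size on the core of compound 2.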